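Hydrazone aryl variation on a shared triazolyl-pyridine ether core

This account rests on a few compounds, and the source may have more. Where it says the series, first, only, none or still open, it means among the compounds named here.

Measured compounds:
- compound 1 `CN(C)CCn1cnnc1-c1cc(Oc2ccc(NC(=O)N/N=C/c3c[nH]c4ccccc34)cc2F)ccn1`: 820 nM
- compound 2 `COc1ccc(/C=N/NC(=O)Nc2ccc(Oc3ccnc(-c4nncn4CCN(C)C)c3)c(F)c2)c(OC)c1OC`: 6680 nM
- compound 3 `CN(C)CCn1cnnc1-c1cc(Oc2ccc(NC(=O)N/N=C/c3ccc(F)cc3F)cc2F)ccn1`: 1870 nM

All three share one core and differ only in the group on a carbon with a double bond to nitrogen. In a functional assay on A549 cells (Homo sapiens) for cytotoxicity, read by MTT assay, with a stated time of 72 h (a lower number here means a stronger inhibitor, a higher number a weaker inhibitor), compound 1 gives 820 nM and holds the lowest number of the three; compound 3 is nearest, compound 2 furthest.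

Compound 4 `CN(C)CCn1cnnc1-c1cc(Oc2ccc(NC(=O)N/N=C/c3cc(Br)c(O)c(Br)c3)cc2F)ccn1` has not been measured in this assay. The change from compound 1 is 3,5-dibromo-4-hydroxyphenyl in place of 1H-indol-3-yl on a carbon with a double bond to nitrogen.

Two measured steps leave the same 1H-indol-3-yl group from the same position: an 8.1-fold higher number from compound 1 to compound 2 (0.91 log units; beyond the scatter) and a 2.3-fold higher number from compound 1 to compound 3 (0.36 log units; beyond the scatter). Both moved the number higher, beyond the scatter, one modestly, one more so. Between the two six-membered replacements, a 3.6-fold lower number from compound 2 to compound 3 (0.55 log units; beyond the scatter). A third six-membered replacement is therefore expected to sit above compound 1, most likely between the two measured outcomes.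

For compound 4 the estimate is 2500 nM, ranging from 900 nM to 7000 nM. The step this estimate implies is a 3.0-fold higher number from compound 1 to compound 4 (0.48 log units; beyond the scatter), expected because a 2.3-fold higher number from compound 1 to compound 3 (0.36 log units; beyond the scatter) and an 8.1-fold higher number from compound 1 to compound 2 (0.91 log units; beyond the scatter) both went the same way.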

Compound 4, half-maximal inhibitory concentration: > 100000 nM
Compound 4: no number, only a limit; the forecaster's own chance of this, stated with the estimate: 5%; middle value at least 40-fold (1.60 log units) away from the limit.
By their numbers in this assay, from the lowest: compound 1; then compound 3; then compound 2. At a limit, above all of these: compound 4.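

In this assay compound 4 stands at a limit and not at a number: the limit of > 100000 nM in this assay, at which 1 of the 4 values shown sits.

Even so, the steps are large: an at least 120-fold higher number from compound 1 to compound 4 (2.08 log units; beyond the scatter), an at least 53-fold higher number from compound 3 to compound 4 (1.72 log units; beyond the scatter) and an at least 14-fold higher number from compound 2 to compound 4 (1.17 log units; beyond the scatter). The position on a carbon with a double bond to nitrogen therefore tolerates far less than the earlier modest steps suggested, and 3,5-dibromo-4-hydroxyphenyl falls well outside the span set by the other two six-membered replacements, despite matching 1H-indol-3-yl in heavy-atom count.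

The compounds shown leave open whether the two bromine atoms, the hydroxyl or only their combination accounts for the change, as all enter together. A phenyl carrying only the hydroxyl or only the bromine atoms would separate these, and a phenyl bearing an amine or a carboxylic acid would test the position further.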